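A few compounds are considered here, and "the series" means these few. Any claim that something is new, unique, unknown or untested is made for them only; others in the source may bear on it.

Compound 1 `Cc1ccc(C(=O)Nc2cccc(-c3oc4cc(-c5ccc(F)cc5)ccc4c(=O)c3O)c2)cc1`: 6910 nM
Compound 2 `Cc1ccccc1C(=O)Nc1cccc(-c2oc3cc(-c4ccc(F)cc4)ccc3c(=O)c2O)c1`: 17600 nM
Compound 3 `O=C(Nc1cccc(-c2oc3cc(-c4ccc(F)cc4)ccc3c(=O)c2O)c1)c1ccc(C(F)(F)F)cc1`: 19400 nM

In a functional assay on A549 cells (Homo sapiens) for antiproliferative activity, read by CCK-8 assay, with a stated time of 72 h (a lower number here means a stronger inhibitor, a higher number a weaker inhibitor), compound 3 carries the highest number of the three: compound 1 sits lower by a 2.8-fold higher number from compound 1 to compound 3 (0.45 log units; beyond the scatter), while compound 2 and compound 3 differ only within the scatter. Compound 4 `COc1cc(OC)cc(C(=O)Nc2cccc(-c3oc4cc(-c5ccc(F)cc5)ccc4c(=O)c3O)c2)c1` keeps the shared core and differs from compound 3 in one place: 3,5-dimethoxyphenyl in place of 4-(trifluoromethyl)phenyl on a carbonyl carbon. Going by the values given here, no measured step introduces the entering group, so the nearest guide is how far swapping the aryl group on the carbonyl carbon has moved the number so far: a 2.5-fold higher number from compound 1 to compound 2 (0.41 log units; beyond the scatter), a 1.1-fold higher number from compound 2 to compound 3 (0.04 log units; within the scatter). Those shifts stayed modest, so for compound 4 a modest shift or none beyond the scatter is expected, leaning slightly toward a lower number: a 1.6-fold lower number from compound 3 to compound 4 (0.21 log units; within the scatter). Compound 4 is therefore estimated at 12000 nM, within 4000 nM to 36000 nM.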

Compound 4, half-maximal inhibitory concentration: 2390 nM
Estimate against measurement, compound 4: 5.0-fold (0.70 log units) above; the measured number lies below the stated range.
By their numbers in this assay, from the lowest: compound 4; then compound 1; then compounds 2 and 3 (each within the scatter of the next).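

In this assay, the aryl group on the carbonyl carbon can move the number further than the earlier swaps showed (an 8.1-fold lower number from compound 3 to compound 4 (0.91 log units; beyond the scatter)) and (a 7.4-fold lower number from compound 2 to compound 4 (0.87 log units; beyond the scatter)). Compound 4 is also the strongest of the four (a 2.9-fold lower number from compound 1 to compound 4 (0.46 log units; beyond the scatter)), so 3,5-dimethoxyphenyl outperforms both methyl-substituted phenyls and 4-(trifluoromethyl)phenyl here. No measurement shown explains this gain. Going by these compounds, whether a single methoxy group would suffice remains open, because these compounds change both methoxy groups together. Also open, on these data alone, is how an amine or a carboxylic acid in their place would fare.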